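A few compounds are considered here, and "the series" means these few. Any claim that something is new, unique, unknown or untested is made for them only; others in the source may bear on it.

Compound 1 `CCN(CC)Cc1c(O)c([C@H]2CCN(C)C[C@H]2O)c2oc(C)cc(=O)c2c1O` gives 24% in a functional assay on MCF7 cells (Homo sapiens) for inhibition, read by MTT assay, with a stated time of 48 h, tested at 10 uM; a lower number here means less inhibition of growth, a higher number more inhibition of growth at the concentration tested. Among the compounds with values here, compound 2 `Cc1cc(=O)c2c(O)c(CN3CCCC3)c(O)c([C@H]3CCN(C)C[C@H]3O)c2o1` gives 12% in this assay; the one measured step, a number 12 percentage points lower from compound 1 to compound 2 (beyond the scatter), is made by pyrrolidin-1-yl in place of diethylamino on a saturated chain carbon bound to an aromatic carbon. Compound 3 `Cc1oc2c([C@H]3CCN(C)C[C@H]3O)c(O)cc(O)c2c(=O)c1C(O)c1ccc([N+](=O)[O-])cc1`, which carries 4-nitrophenyl on a saturated chain carbon bound to an aromatic carbon and an oxygen on a saturated carbon, gives 4% in this assay, the lowest of the three numbers shown: the gap to compound 2 lies within the scatter, the gap to compound 1 beyond it.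

Compound 4 `CCOc1ccc(Br)c(C(O)c2c(C)oc3c([C@H]4CCN(C)C[C@H]4O)c(O)cc(O)c3c2=O)c1` differs from compound 3 in one place: 2-bromo-5-ethoxyphenyl in place of 4-nitrophenyl on a saturated chain carbon bound to an aromatic carbon and an oxygen on a saturated carbon. Within the data shown here, no measured step touches this position; the single step in hand, a number 12 percentage points lower from compound 1 to compound 2 (beyond the scatter), concerns the amine on the chain carbon and gives no guide to exchanging one aryl group for another at the carbon bearing the hydroxyl. With nothing bearing on the change, no step beyond the scatter is expected in this assay, and the step from compound 3 to compound 4 is estimated as a number 4 percentage points higher from compound 3 to compound 4 (within the scatter). Compound 4 is therefore expected to give about 8% in this assay, within 0% to 25%.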

Compound 4, percent growth inhibition at one concentration: 9%
Compound 4: the middle estimate sits 1 percentage points below what was measured; the measured number falls inside the stated range.
By their numbers in this assay, from the lowest: compounds 3, 4 and 2 (each within the scatter of the next); then compound 1.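

In this assay, within the data shown here, the exchange on the saturated chain carbon bound to an aromatic carbon and an oxygen on a saturated carbon gives a number 5 percentage points higher from compound 3 to compound 4 (within the scatter), the first reading at this position. Replacing 4-nitrophenyl with 2-bromo-5-ethoxyphenyl swaps a group holding nitrogen and two oxygens for one holding bromine and a single oxygen, yet this does not separate the two compounds in this assay, where compound 4 gives 9%; at this position, these two aryl groups cannot be told apart. No measurement at hand bears on why the two groups read alike.

On these data alone, it remains open whether any group at this carbon can move the number beyond the scatter, for example an unsubstituted phenyl, a phenyl carrying a carboxylic acid or a primary amine, or a longer alkyl chain in place of the aryl ring. Also open, as far as these compounds go, is what the hydroxyl on this carbon contributes, which a direct comparison with a methylene at the same place would show, and whether the aryl exchange reads the same with a diethylamino or pyrrolidin-1-yl group on the chain carbon.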